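The compounds below may be only part of what the source reports. "The series", "measured", "known", "first", "only" and "open" are said of these compounds alone.

Compound 1 `CN(C)CCCn1c(N)c(-c2nc3ccccc3n2C)c2nc(C#N)c(C#N)nc21` carries a 3-(dimethylamino)propyl chain on its core, and in a functional assay on Raji cells (Homo sapiens) for antiproliferative activity, read by MTT assay, with a stated time of 48 h (on this read-out higher numbers stand for weaker inhibition and lower numbers for stronger inhibition), compound 1 gives 940 nM. Compound 2 `CCN(CC)CCCn1c(N)c(-c2nc3ccccc3n2C)c2nc(C#N)c(C#N)nc21` differs by diethylamino in place of dimethylamino on a saturated chain carbon, three bonds along the chain from an aromatic nitrogen, and in this assay compound 2 gives 2220 nM; the step of a 2.4-fold higher number from compound 1 to compound 2 (0.37 log units; beyond the scatter) is thus modest but beyond the scatter.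

Compound 3 `CN(C)CCn1c(N)c(-c2nc3cc(Cl)ccc3[nH]2)c2nc(C#N)c(C#N)nc21` is built on a different core; how the core of compound 3 differs from the core of compound 1 is not broken down here. In this assay compound 3 gives 11800 nM, the highest number among the three measured compounds, with compound 2 nearest and compound 1 furthest from it.

Compound 4 `CCN(CC)CCn1c(N)c(-c2nc3cc(Cl)ccc3[nH]2)c2nc(C#N)c(C#N)nc21` is not yet measured. It differs from compound 3 by diethylamino in place of dimethylamino on a saturated chain carbon, two bonds along the chain from an aromatic nitrogen. This is the same kind of change as that from compound 1 to compound 2, though the place differs: there the chain was three bonds along from the aromatic nitrogen, here it is two. Resting on the step of a 2.4-fold higher number from compound 1 to compound 2 (0.37 log units; beyond the scatter), the expected step for compound 4 is a 2.1-fold higher number from compound 3 to compound 4 (0.33 log units; beyond the scatter), with wider uncertainty because the core and chain length differ from the pair that supplies the precedent. In this assay compound 4 is therefore estimated at 25000 nM, expected to lie between 8000 nM and 80000 nM.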

Compound 4, half-maximal inhibitory concentration: 31500 nM
Compound 4: middle estimate off by 1.3-fold (0.10 log units), on the low side; the measured number falls inside the stated range.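

In this assay, diethylamino in place of dimethylamino on the chain gives a 2.7-fold higher number from compound 3 to compound 4 (0.43 log units; beyond the scatter), a modest step in the same direction as the earlier one. On the two cores shown, the change therefore carries over with much the same size: the same change on two cores in this assay, a 2.4-fold higher number (0.37 log units; beyond the scatter) from compound 1 to compound 2 and a 2.7-fold higher number (0.43 log units; beyond the scatter) from compound 3 to compound 4, 1.1-fold (0.05 log units) apart, within the scatter of two such steps

Within the data shown here, this agreement rests on only two pairs, and these differ in core and chain length together, so it does not show how each of those differences alone bears on the step, nor that the step would hold on any further core.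

The compounds shown leave open how a ring amine, such as piperidine or morpholine, or a larger open-chain amine, such as dipropylamino, would read in this position. They also leave open whether the step would keep its size on a longer chain, or with the chlorine of compound 3 and compound 4 replaced by fluorine or a methoxy group.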